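From Dimethylamino to Trifluoromethyl: an Expected Shift in Inhibition

The compounds below may be only part of what the source reports. "The series", "measured", "known", "first", "only" and "open" are said of these compounds alone.

Compound 1 `CCOc1ccc(C(=O)/C=C/c2ccc(F)cc2)cc1` and compound 2 `CCOc1ccc(C(=O)/C=C/c2ccc(N(C)C)cc2)cc1` share one core and differ in a single group. Among the compounds with values here, in an assay on isolated protein for inhibition of Amine oxidase [flavin-containing] B (Homo sapiens) (a higher number here means a weaker inhibitor, a lower number a stronger inhibitor), compound 1 gives 53 nM, while compound 2 gives 210 nM, the highest of the two numbers measured so far. The step of a 4.0-fold higher number from compound 1 to compound 2 (0.60 log units; beyond the scatter) came with dimethylamino in place of fluoro on an aromatic carbon. Compound 3 `CCOc1ccc(C(=O)/C=C/c2ccc(C(F)(F)F)cc2)cc1` carries trifluoromethyl in place of dimethylamino on an aromatic carbon. Within the data shown here, only that one measured step bears on this change, and it runs in the opposite sense: replacing fluoro with dimethylamino raised the number, so taking dimethylamino away again in favour of trifluoromethyl is expected to bring the number back toward that of compound 1 rather than beyond it. Compound 3 is therefore estimated at 70 nM in this assay, between 25 nM and 220 nM, a step of a 3.0-fold lower number from compound 2 to compound 3 (0.48 log units; beyond the scatter) that is expected to lie beyond the scatter.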

Compound 3, half-maximal inhibitory concentration: 210 nM
Compound 3: the middle estimate sits 3.0-fold (0.48 log units) below what was measured; low and high end bracket the measured number.
By their numbers in this assay, from the lowest: compound 1; then compounds 2 and 3 (each within the scatter of the next).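

In this assay, trifluoromethyl in place of dimethylamino gives no change at the digits printed from compound 2 to compound 3 (within the scatter) and so does not bring the number back toward that of the fluoro compound, which shows that moving away from dimethylamino is not enough on its own at this position. Trifluoromethyl in place of fluoro gives a 4.0-fold higher number from compound 1 to compound 3 (0.60 log units; beyond the scatter) and matches the earlier step, so among these three compounds fluoro alone stands apart, while the hydrogen-bond acceptor counted for dimethylamino and absent from trifluoromethyl makes no difference that can be read here. Nothing available accounts for this result.

From the compounds shown here alone, whether a low number is particular to fluoro remains open, since chloro, a nitrile or a plain hydrogen at this position could read either way. The compounds shown also leave open whether the same order would hold on a core carrying a longer chain in place of its ethoxy group.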